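Chlorophenyl to chlorohydroxyphenyl in a dienone series

The compounds below may be only part of what the source reports. "The series", "measured", "known", "first", "only" and "open" are said of these compounds alone.

Three compounds have numbers in a functional assay on MCF7 cells (Homo sapiens) for cytotoxicity, read by MTT assay, with a stated time of 72 h; on this read-out higher numbers stand for weaker inhibition and lower numbers for stronger inhibition. Compound 1 `COc1cccc(/C=C2\CCC/C(=C\c3cccc(Cl)c3)C2=O)c1OC` gives 12000 nM, compound 2 `COc1cc(/C=C2\CCC/C(=C\c3cccc(OC)c3OC)C2=O)ccc1O` gives 11600 nM, and compound 3 `COc1ccc(/C=C2\CCC/C(=C\c3ccc(Cl)cc3)C2=O)cc1OC` gives 6300 nM. Compound 3 holds the lowest of the three numbers, but its gaps to compound 2 and to compound 1 both lie within the scatter, so no ordering is claimed.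

Compound 4 `COc1ccc(/C=C2\CCC/C(=C\c3ccc(O)c(Cl)c3)C2=O)cc1OC` differs from compound 3 in one place: 3-chloro-4-hydroxyphenyl in place of 4-chlorophenyl on a double-bonded chain carbon bound to a double-bonded ring carbon. Going by the values given here, the only measured step that bears on this, a hydroxyl entering the aryl ring at the same place, is a 1.0-fold lower number from compound 1 to compound 2 (0.01 log units; within the scatter), within the scatter. No step beyond the scatter is therefore expected in this assay; the estimated step is a 1.0-fold higher number from compound 3 to compound 4 (0.01 log units; within the scatter). Compound 4 is expected at 6500 nM, between 2800 nM and 15000 nM.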

Compound 4, half-maximal inhibitory concentration: 12300 nM
Compound 4: the middle estimate sits 1.9-fold (0.28 log units) below what was measured, and the stated range covers the measured number.
By their numbers in this assay, from the lowest: compounds 3, 2, 1 and 4 (each within the scatter of the next).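

In this assay, 3-chloro-4-hydroxyphenyl in place of 4-chlorophenyl on a double-bonded chain carbon bound to a double-bonded ring carbon gives a 2.0-fold higher number from compound 3 to compound 4 (0.29 log units; within the scatter). This place therefore takes a group with a hydrogen-bond donor and a hydrogen-bond acceptor without a step beyond the scatter, even with the chlorine retained on the ring. The same holds for the earlier swap of 3-chlorophenyl, a 1.0-fold lower number from compound 1 to compound 2 (0.01 log units; within the scatter).

On these data alone, the effect of a carboxylic acid or an amine at this place remains open. Nothing in hand explains the readings of compound 3 and compound 4.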